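Notes on an aryl swap in a dosed series

The source may report more compounds than this note shows. Statements on the series, on what has been measured and on what is new or still open speak of the compounds shown alone.

Measured so far:
- compound 1 `CC1CCC(=NNc2ccccc2C(=O)O)c2ncc(C(=O)O)c(=O)n21`: in a functional assay on the whole organism with Rattus norvegicus as the target (on this read-out higher numbers stand for an effect only at larger amounts of compound and lower numbers for an effect already at smaller amounts), compound 1 gives > 100 umol/kg, a limit of the assay.
- compound 2 `Cc1cccc(NN=C2CCC(C)n3c2ncc(C(=O)O)c3=O)c1C`: in this assay compound 2 gives > 100 umol/kg, also a limit.

For the measured compounds named here, compound 2 therefore stands nowhere on a numerical scale: its value is a limit only, and the one further value shown is a limit as well, both sitting at the limit of > 100 umol/kg in this assay, at which 2 of the 2 values shown sit. Going by the values given here, no step between measured compounds can be formed from two limits, so nothing about the size or direction of any change is known.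

Compound 3 `CC1CCC(=NNc2ccc(Cl)cc2Cl)c2ncc(C(=O)O)c(=O)n21` is the next member, differing from compound 2 by 2,4-dichlorophenyl in place of 2,3-dimethylphenyl on an amine nitrogen. With both measured values at the limit, no step beyond the scatter is expected from this exchange. Compound 3 is estimated to give 150 umol/kg in this assay, with a range of 50 umol/kg to 500 umol/kg. The step that the limit leaves unreadable from compound 2 to compound 3 is expected to be none beyond the scatter, and a further limit is the most likely outcome.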

Compound 3, dose for 50% inhibition: > 100 umol/kg
Compound 3: only a limit was reported (the forecaster's own chance of this, stated with the estimate: 70%); the middle value lies beyond the limit too.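

In this assay compound 3 gives > 100 umol/kg as a limit of the assay. No step can be read between compound 2 and compound 3, and all values shown sit at one limit: the limit of > 100 umol/kg in this assay, at which 3 of the 3 values shown sit.

The compounds shown leave open whether any aryl group on the amine nitrogen in this assay gives a readable dose for inhibition.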